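Dichloroacetamide biaryls: taking away a methoxy group

A few compounds are considered here, and "the series" means these few. Any claim that something is new, unique, unknown or untested is made for them only; others in the source may bear on it.

Three dichloroacetanilides bearing a second aromatic ring have been tested in a functional assay on A549 cells (Homo sapiens) for cytotoxicity, read by MTT assay, with a stated time of 68 h; on this read-out lower numbers stand for stronger inhibition and higher numbers for weaker inhibition. Compound 1 `O=C(Nc1cccc(-c2ccsc2)c1)C(Cl)Cl` gives only a limit in this assay, > 50000 nM, one of the cases counted in the limit of > 50000 nM in this assay, at which 1 of the 3 values shown sits. Compound 2 `O=C(Nc1cccc(-c2ccccc2Cl)c1)C(Cl)Cl` gives 22600 nM in this assay. Compound 3 `COc1ccc(-c2cccc(NC(=O)C(Cl)Cl)c2)cc1` gives 8530 nM, the lowest of the two numbers, and its gap to compound 2 lies beyond the usual scatter. The next compound, compound 4 `O=C(Nc1cccc(-c2ccccc2)c1)C(Cl)Cl`, differs from compound 3 in one place: hydrogen in place of methoxy on an aromatic carbon. Among the measured compounds shown here, no measured step of this kind is available, so the step of a 1.8-fold higher number from compound 3 to compound 4 (0.25 log units; within the scatter) is expected to be a modest loss, possibly still within the scatter. Compound 4 is therefore estimated at 15000 nM, within a range from 5000 nM to 45000 nM.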

Compound 4, half-maximal inhibitory concentration: 8900 nM
For compound 4 the middle estimate is 1.7-fold (0.23 log units) above the measured one; the measured number falls inside the stated range.
By their numbers in this assay, from the lowest: compounds 3 and 4 (each within the scatter of the next); then compound 2. At a limit, above all of these: compound 1.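

In this assay the methoxy group on this aromatic carbon turns out to be dispensable: hydrogen in its place gives a 1.0-fold higher number from compound 3 to compound 4 (0.02 log units; within the scatter). The unsubstituted phenyl ring also compares well with the other two compounds: hydrogen in place of chloro gives a 2.5-fold lower number from compound 2 to compound 4 (0.40 log units; beyond the scatter), and phenyl in place of thiophen-3-yl gives an at least 5.6-fold lower number from compound 1 to compound 4 (0.74 log units; beyond the scatter). The last of these steps rests on a limit and not on a number: the limit of > 50000 nM in this assay, at which 1 of the 4 values shown sits.

As far as these compounds go, whether an amine or a carboxylic acid on this same carbon would shift the number beyond the scatter remains open.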